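The source may hold more compounds than are shown below. What is called first, only, known or untested is meant among the compounds shown, and "the series" means these compounds.

For the measured compounds named here, compound 1 `Nc1ccc(-n2c(-c3cccnc3N)nc3cccnc32)cc1` is the only compound here with a numerical result: in an in vitro assay on Sf9 cells for inhibition of RAC-alpha serine/threonine-protein kinase (Homo sapiens), read by AlphaScreen, with a stated time of 20 min (a lower number here means a stronger inhibitor, a higher number a weaker inhibitor), compound 1 gives 740 nM. Compound 2 `COc1ccccc1Cn1c(-c2ccncc2)nc2cc(Br)cnc21` stands apart. In this assay compound 2 returns > 300000 nM, which is a limit of the test and not a number. This is the limit of > 300000 nM in this assay, at which 1 of the 2 values shown sits. Going by the values given here, no two measured compounds differ in a single place, so no measured step exists to guide the comparison. Compound 3 `CC(=O)NCc1ccc(-n2c(-c3cccnc3N)nc3cccnc32)cc1` differs from compound 1 by one change, acetamidomethyl in place of amino on an aromatic carbon. The expectation for compound 3 therefore rests on compound 1 alone and on the size of the change. The step expected in this assay is a 2.4-fold higher number from compound 1 to compound 3 (0.39 log units; beyond the scatter), a loss somewhat beyond the usual scatter. Among the compounds with values here, no measured pair either supports or contradicts this. Compound 3 is expected to give 1800 nM, most likely between 350 nM and 9000 nM.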

Compound 3, half-maximal inhibitory concentration: 810 nM
Compound 3: the middle estimate sits 2.2-fold (0.35 log units) above what was measured, within the range that was stated.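

Replacing amino with acetamidomethyl on an aromatic carbon, para to a large group, gives a 1.1-fold higher number from compound 1 to compound 3 (0.04 log units; within the scatter) in this assay, so the two compounds cannot be told apart in this test. For the compounds shown here, this is the first measured step at this position, and it shows that a group of 5 heavy atoms can take the place of a group of 1 heavy atom without the number moving beyond the usual scatter. Nothing measured here explains why the number holds steady.

From the compounds shown here alone, it remains open whether other groups at this position would fare the same, such as a carboxylic acid, a methyl or a longer chain ending in an amine. A single pair also cannot show whether this result would carry over to a different core.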